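Shortening the Chain of Compound 3

The compounds below may be only part of what the source reports. "The series", "measured", "known", "first", "only" and "open" are said of these compounds alone.

Of the compounds shown here, three have been measured in a functional assay, read by fluorescence and spectrophotometry, with a stated time of 1 h; on this read-out higher numbers stand for an effect only at larger amounts of compound and lower numbers for an effect already at smaller amounts.
Compound 1 `CCCCCCCCCCCCS(=O)(=O)/C=C/c1ccc(O)c(O)c1` gives 8500 nM.
Compound 2 `C=CCCCCCS(=O)(=O)/C=C/c1ccc(O)c(O)c1` gives 7100 nM.
Compound 3 `O=S(=O)(/C=C/c1ccc(O)c(O)c1)CCCCCCCCO` gives 6700 nM.

Compound 3 has the lowest of the three numbers, but all three lie close together: a 1.2-fold lower number from compound 1 to compound 2 (0.08 log units; within the scatter), a 1.3-fold lower number from compound 1 to compound 3 (0.10 log units; within the scatter), and a 1.1-fold lower number from compound 2 to compound 3 (0.03 log units; within the scatter), each within the scatter. The chain on the sulfonyl sulfur has so far been varied at its far end without a clear effect in this assay.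

Compound 4 `CCCCCS(=O)(=O)/C=C/c1ccc(O)c(O)c1` takes the chain of compound 3 and cuts it short: hydrogen in place of 3-hydroxypropyl on a saturated chain carbon, five bonds along the chain from a sulfonyl sulfur. For the measured compounds named here, every measured step that changed this chain stayed within the scatter, so the change to compound 4 is expected to bring no step beyond the scatter either, although this change removes the 3-hydroxypropyl outright rather than trading one chain end for another, and no measured step covers that exactly. Compound 4 is therefore expected to give about 7000 nM, between 3000 nM and 17000 nM, an expected step of a 1.0-fold higher number from compound 3 to compound 4 (0.02 log units; within the scatter).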

Compound 4, half-maximal effective concentration: 8100 nM
Beside the measured number, compound 4's estimate is 1.2-fold (0.06 log units) below it, and the stated range covers the measured number.
By their numbers in this assay, from the lowest: compounds 3, 2, 4 and 1 (each within the scatter of the next).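

Removing the 3-hydroxypropyl outright, with hydrogen in its place on this saturated chain carbon, keeps the number in this assay within the scatter (a 1.2-fold higher number from compound 3 to compound 4 (0.08 log units; within the scatter)). Hydrogen in place of vinyl (a 1.1-fold higher number from compound 2 to compound 4 (0.06 log units; within the scatter)) and hydrogen in place of heptyl (a 1.0-fold lower number from compound 1 to compound 4 (0.02 log units; within the scatter)) also stay within the scatter, so in these four compounds neither shortening the chain at this carbon nor its hydroxy or vinyl end separates the numbers, and no compound goes against this. Nothing available explains why this position tolerates these changes.

Going by these compounds, whether a carboxylic acid or an amine on this carbon would bring a step beyond the scatter remains open. So does the effect of a much shorter chain on the sulfonyl sulfur, such as methyl or ethyl.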